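Compound 4: cyclopropyl amide, permeability expectation

A few compounds are considered here, and "the series" means these few. Any claim that something is new, unique, unknown or untested is made for them only; others in the source may bear on it.

Compound 2 `CNC(=O)c1cc(C(=O)N[C@H]2CC[C@H](O)CC2)n([C@@H](C)c2ccccc2)n1` gives 80 nm/s in an ADME assay for permeability (a higher number here means that the compound crosses the layer faster, a lower number that the compound crosses the layer more slowly), and stands second highest of the three numbers measured. Compound 1 `CNC(=O)c1cc(C(=O)N[C@H]2CC[C@H](O)CC2)n([C@@H](C)c2ccc(Cl)cc2)n1` gives 180 nm/s in this assay; compound 3 `CC[C@@H](c1ccccc1)n1nc(C(=O)NC)cc1C(=O)N[C@H]1CC[C@H](O)CC1` gives 70 nm/s in this assay. Every step measured so far alters the group on the aromatic nitrogen: a 2.3-fold lower number from compound 1 to compound 2 (0.35 log units; beyond the scatter), a 2.6-fold lower number from compound 1 to compound 3 (0.41 log units; beyond the scatter) and a 1.1-fold lower number from compound 2 to compound 3 (0.06 log units; within the scatter). Compound 4 `CNC(=O)c1cc(C(=O)NC2CC2)n([C@@H](C)c2ccccc2)n1` instead differs from compound 2 at the amide-type nitrogen: cyclopropyl in place of 4-hydroxycyclohexyl on an amide-type nitrogen. Among the measured compounds shown here, no measured step touches this position, so none of them bears directly on the change, and the expectation rests on the value of compound 2 alone. The step expected in this assay is a 2.5-fold higher number from compound 2 to compound 4 (0.40 log units; beyond the scatter), towards a higher number, with wide uncertainty. For compound 4 the estimated value in this assay is 200 nm/s, within a range of 90 nm/s to 450 nm/s.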

Compound 4, apparent permeability: > 400 nm/s
Compound 4: a limit, no number; the forecaster's own chance of this, stated with the estimate: 5%; middle value at least 2.0-fold (0.30 log units) from the limit.
By their numbers in this assay, from the lowest: compounds 3 and 2 (each within the scatter of the next); then compound 1. At a limit, above all of these: compound 4.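

Changing the group on the amide-type nitrogen moves the number in this assay further than any measured change on the aromatic nitrogen: cyclopropyl in place of 4-hydroxycyclohexyl gives an at least 5.0-fold higher number from compound 2 to compound 4 (0.69 log units; beyond the scatter) on the shared core. For compound 4 the reading is a limit and not a number: the limit of > 400 nm/s in this assay, at which 1 of the 4 values shown sits.

This change swaps the ring and removes the hydroxyl together, and the compounds shown do not separate the two. Open, on these data alone, is what plain cyclohexyl, 4-methoxycyclohexyl or an open-chain alkyl group on the same nitrogen would give.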